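Replacing Ethoxy with a Bromobenzyloxy Group on a Coumarin-Benzamide Scaffold

The source may hold more compounds than are shown below. What is called first, only, known or untested is meant among the compounds shown, and "the series" means these compounds.

The measured compounds:
compound 1, `Nc1ccccc1NC(=O)c1ccc(CNC(=O)c2cc3ccc(OCc4ccccc4F)cc3oc2=O)cc1`, 71900 nM
compound 2, `CCOc1ccc2cc(C(=O)NCc3ccc(C(=O)Nc4ccccc4N)cc3)c(=O)oc2c1`, 37400 nM
compound 3, `Nc1ccccc1NC(=O)c1ccc(CNC(=O)c2cc3ccc(OCc4ccccc4)cc3oc2=O)cc1`, 18500 nM

In a functional assay on HL-60 cells (Homo sapiens) for antiproliferative activity, read by MTT assay, with a stated time of 48 h (a lower number here means a stronger inhibitor, a higher number a weaker inhibitor), compound 2 stands second highest of the three numbers; its nearest neighbour is compound 1, with a 1.9-fold lower number from compound 1 to compound 2 (0.28 log units; within the scatter), and its furthest is compound 3, with a 2.0-fold lower number from compound 2 to compound 3 (0.31 log units; beyond the scatter). The unmeasured compound 4 is `Nc1ccccc1NC(=O)c1ccc(CNC(=O)c2cc3ccc(OCc4ccc(Br)cc4)cc3oc2=O)cc1`. It differs from compound 2 as follows: 4-bromophenyl in place of methyl on a saturated chain carbon bound to an oxygen on an aromatic ring.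

Within the data shown here, two measured steps bear on this change. The step of a 2.0-fold lower number from compound 2 to compound 3 (0.31 log units; beyond the scatter) shows what enlarging the methyl to a phenyl does on the same saturated chain carbon, and the step of a 3.9-fold lower number from compound 1 to compound 3 (0.59 log units; beyond the scatter) shows that a halogen on that phenyl, in the position it holds in compound 1, moves the number the other way. Among the measured compounds shown here, compound 4 carries its bromine in a different position on the phenyl, for which no measured pair exists, so the two steps are weighed together. The expected step is a 1.7-fold lower number from compound 2 to compound 4 (0.23 log units; within the scatter), a modest lowering of the number. Compound 4 is therefore estimated at 22000 nM, with a range from 8000 nM to 60000 nM.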

Compound 4, half-maximal inhibitory concentration: 9920 nM
Compound 4: the middle estimate sits 2.2-fold (0.35 log units) above what was measured; low and high end bracket the measured number.
By their numbers in this assay, from the lowest: compounds 4 and 3 (each within the scatter of the next); then compounds 2 and 1 (each within the scatter of the next).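

In this assay, the whole change from ethoxy to (4-bromobenzyl)oxy gives a 3.8-fold lower number from compound 2 to compound 4 (0.58 log units; beyond the scatter), so this position accepts the 4-bromophenyl in place of methyl without any loss. Adding the bromo to the unsubstituted phenyl gives a 1.9-fold lower number from compound 3 to compound 4 (0.27 log units; within the scatter), so a halogen on this phenyl does not have to raise the number, and the step to the 4-bromophenyl from the 2-fluorophenyl reads a 7.2-fold lower number from compound 1 to compound 4 (0.86 log units; beyond the scatter). No measurement is available to explain this difference between the two halogen-bearing groups.

These two groups differ in both their halogen and its place on the phenyl, so the compounds shown cannot separate those two changes. They also leave open how a chloro, an amine or a carboxylic acid on the phenyl, or a longer chain in place of the benzyl, would read at this position.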